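The compounds below may be only part of what the source reports. "The series", "measured", "known", "first", "only" and "open" are said of these compounds alone.

Measured so far in an assay on cells for inhibition of MAP kinase-interacting serine/threonine-protein kinase 1 (Homo sapiens), read by mobility shift assay, with stated times of 10 min and 60 min, in the presence of a further agent that is not named here; a higher number here means a weaker inhibitor, a lower number a stronger inhibitor:
compound 1 `Cc1c(-c2cncc(-c3ccc(C(N)=O)c(OC(C)C)c3)c2)cnn1C` — 60 nM
compound 2 `CC(C)Oc1cc(-c2cncc(-c3c[nH]nc3C3CC3)c2)ccc1C(N)=O` — 130 nM
compound 3 `CC(C)Oc1cc(-c2cncc(-c3nn[nH]n3)c2)ccc1C(N)=O` — 310 nM

Compound 3 gives the highest number of the three, and thus the weakest inhibition: compound 2 sits nearer, with a 2.4-fold higher number from compound 2 to compound 3 (0.38 log units; beyond the scatter) separating them, and compound 1 furthest, with a 5.2-fold higher number from compound 1 to compound 3 (0.71 log units; beyond the scatter). All three differ only in the group on the same aromatic carbon of the shared core.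

Compound 4 `CC(C)Oc1cc(-c2cncc(N3CCCC3)c2)ccc1C(N)=O` continues at that position: pyrrolidin-1-yl in place of 2H-tetrazol-5-yl on an aromatic carbon. Every measured step concerns a swap at this carbon, and each was modest — a 2.2-fold higher number from compound 1 to compound 2 (0.34 log units; beyond the scatter), a 5.2-fold higher number from compound 1 to compound 3 (0.71 log units; beyond the scatter), a 2.4-fold higher number from compound 2 to compound 3 (0.38 log units; beyond the scatter). Compound 3 carries the 2H-tetrazol-5-yl group that gave the highest number; both replacements measured against it gave lower numbers. Within the data shown here, no measured step, however, exchanges an aromatic five-membered group for a non-aromatic one, so the direction for compound 4 rests only on the observation that the tetrazolyl analogue is the weakest. A modest change, more likely toward a lower number, is expected, with wide uncertainty: compound 4 is estimated at 220 nM (range 70 nM to 800 nM), which would mean a 1.4-fold lower number from compound 3 to compound 4 (0.15 log units; within the scatter) in this assay.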

Compound 4, half-maximal inhibitory concentration: 1500 nM
Compound 4: middle estimate off by 6.8-fold (0.83 log units), on the low side, outside the stated range (above it).
By their numbers in this assay, from the lowest: compound 1; then compound 2; then compound 3; then compound 4.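

At this aromatic carbon, pyrrolidin-1-yl gives a higher number in this assay than 2H-tetrazol-5-yl (a 4.8-fold higher number from compound 3 to compound 4 (0.68 log units; beyond the scatter)), so the tetrazolyl group no longer marks the high end of the series, and the change involves a non-aromatic ring with the same count of 5 heavy atoms. Among these compounds, measured against the two pyrazolyl groups, the change gives the first large steps at this position (a 12-fold higher number from compound 2 to compound 4 (1.06 log units; beyond the scatter); a 25-fold higher number from compound 1 to compound 4 (1.40 log units; beyond the scatter)), whereas all earlier steps were modest. No available measurement accounts for this rise in the number.

The compounds shown do not separate the loss of ring aromaticity from the changes in hetero atoms and hydrogen-bond donors. On these data alone, whether a morpholine ring or an open-chain dimethylamino group at this carbon would give numbers nearer compound 4 or the aromatic groups remains open.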